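The source may hold more compounds than are shown below. What is called first, only, known or untested is meant among the compounds shown, and "the series" means these compounds.

The three measured compounds share one core, seen in compound 1 `O=C(Nc1ccc(NCC2CCCC2)cc1Cl)c1cc(Cl)ccc1O`. In an ADME assay on A549 cells (Homo sapiens) for cytotoxicity, read by resazurin assay, with a stated time of 48 h (on this read-out higher numbers stand for lower toxicity in this test and lower numbers for higher toxicity in this test), compound 1 gives 21500 nM, which is the highest of the three numbers. Compound 2 `CCCN(CCC)c1ccc(NC(=O)c2cc(Cl)ccc2O)c(Cl)c1` gives 10700 nM in this assay, and compound 3 `O=C(Nc1ccc(N(CC2CC2)CC2CC2)cc1Cl)c1cc(Cl)ccc1O` gives 12800 nM. The steps from compound 1 to its neighbours are small: a 2.0-fold lower number from compound 1 to compound 2 (0.30 log units; within the scatter) and a 1.7-fold lower number from compound 1 to compound 3 (0.23 log units; within the scatter); between the two other amines, a 1.2-fold higher number from compound 2 to compound 3 (0.08 log units; within the scatter).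

Compound 4 `O=C(Nc1ccc(NCc2cc(Cl)cc(Cl)c2)cc1Cl)c1cc(Cl)ccc1O` differs from compound 1 by 3,5-dichlorophenyl in place of cyclopentyl on a saturated chain carbon bound to a nitrogen on an aromatic ring. Within the data shown here, none of the measured steps exchanges a saturated ring for an aromatic one; they only vary the groups carried by the nitrogen on the aromatic ring, and every one of them stayed inside the scatter. Among the measured compounds shown here, with no step bearing directly on this change, the most reasonable expectation for compound 4 is a step of a 1.3-fold lower number from compound 1 to compound 4 (0.10 log units; within the scatter), that is, nothing beyond the scatter in either direction. Compound 4 is therefore estimated at 17000 nM in this assay, with a range from 7000 nM to 40000 nM.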

Compound 4, half-maximal cytotoxic concentration: 13300 nM
The estimate for compound 4 lay 1.3-fold (0.11 log units) above the measured number; low and high end bracket the measured number.
By their numbers in this assay, from the lowest: compounds 2, 3, 4 and 1 (each within the scatter of the next).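

In this assay, 3,5-dichlorophenyl in place of cyclopentyl on a saturated chain carbon bound to a nitrogen on an aromatic ring gives a 1.6-fold lower number from compound 1 to compound 4 (0.21 log units; within the scatter). Unlike the earlier steps, which only exchanged saturated groups on that nitrogen, this one brings in an aromatic ring and two chlorine atoms, and even so the number does not move beyond the scatter. Nothing available explains this result.

The compounds shown leave open whether an unsubstituted benzyl, a benzyl with a single chlorine or a pyridylmethyl group would behave the same way at this place. They also do not tell whether a chain ending in a carboxylic acid or a basic amine would stay within the scatter of compound 1.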